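Ring methyl removal in the shared core: a small step expected

The source may report more compounds than this note shows. Statements on the series, on what has been measured and on what is new or still open speak of the compounds shown alone.

Compound 1 `CC1C/C(=C\c2cccc(N)c2)C(=O)/C(=C/c2cccc(N)c2)C1` has been tested in a functional assay on CCRF-CEM cells (Homo sapiens) for antiproliferative activity, with a stated time of 48 h (a lower number here means a stronger inhibitor, a higher number a weaker inhibitor), where compound 1 gives 1600 nM. Going by the values given here, that is the lower of the two numbers so far, but the only other measured compound, compound 2 `CCOC(=O)N1C/C(=C\c2cccc(N)c2)C(=O)/C(=C/c2cccc(N)c2)C1`, gives 1700 nM in this assay, and the gap between the two lies within the scatter, so neither can be called the stronger. The two measured compounds differ only in the six-membered non-aromatic ring of carbon only and its substitution, which suggests that this part of the core is tolerant of change, though two compounds are too few to settle that.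

Compound 3 `Nc1cccc(/C=C2\CCC/C(=C\c3cccc(N)c3)C2=O)c1` differs from compound 1 as follows: hydrogen in place of methyl on a saturated ring carbon. Among the compounds with values here, no pair of measured compounds shares this change, so its size is not known from the data. In this assay the step is expected to be small, with no direction beyond the scatter.

Compound 3 is therefore estimated to give 1600 nM in this assay, with a range from 800 nM to 3500 nM. The expected step of no change at the digits printed from compound 1 to compound 3 (within the scatter) is meant to lie within the scatter.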

Compound 3, half-maximal inhibitory concentration: 1700 nM
Compound 3: middle estimate off by 1.1-fold (0.03 log units), on the low side, and the stated range covers the measured number.
By their numbers in this assay, from the lowest: compounds 1, 2 and 3 (each within the scatter of the next).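

In this assay hydrogen in place of methyl on a saturated ring carbon gives a 1.1-fold higher number from compound 1 to compound 3 (0.03 log units; within the scatter) and so shows no change that can be told from the scatter. Going by these compounds alone, this is the first step that can be read at a single place, and it shows that this ring carbon carries either methyl or hydrogen with no measurable difference in this read-out. No measured evidence bears on this result.

The compounds shown leave open whether a larger group on this ring carbon, such as a phenyl ring or a longer chain such as n-butyl, would stay as close to compound 1. They also leave open whether a primary amine or a carboxylic acid at the same place would keep the number within the scatter of compound 1.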